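Exchanging the trifluoromethyl ring for a fluoro-methyl ring

The compounds below may be only part of what the source reports. "The series", "measured", "known", "first", "only" and "open" are said of these compounds alone.

Compound 3 `C=CCn1c(=O)/c(=C\c2ccccc2C(F)(F)F)[nH]c(=O)/c1=C\c1ccccc1OC` gives 5100 nM in a functional assay on BGC-823 cells (Homo sapiens) for cytotoxicity, read by CCK-8 assay, with a stated time of 72 h (a lower number here means a stronger inhibitor, a higher number a weaker inhibitor), the middle of three numbers, standing between compound 1 `C=CCn1c(=O)/c(=C\c2cccc(Cl)c2Cl)[nH]c(=O)/c1=C\c1ccccc1OC` at 2200 nM and compound 2 `C=CCn1c(=O)/c(=C\c2ccccc2OC)[nH]c(=O)/c1=C\c1ccccc1OC` at 13400 nM. The change to compound 4 `C=CCn1c(=O)/c(=C\c2cc(F)ccc2C)[nH]c(=O)/c1=C\c1ccccc1OC` is 5-fluoro-2-methylphenyl in place of 2-(trifluoromethyl)phenyl on a double-bonded chain carbon bound to an aromatic carbon. Going by the values given here, two measured steps bear on it: a 2.6-fold lower number from compound 2 to compound 3 (0.42 log units; beyond the scatter), and a 2.3-fold higher number from compound 1 to compound 3 (0.37 log units; beyond the scatter), so compound 1 gave the lowest number and compound 2 the highest. Compound 4 again brings a halogen to this ring together with a methyl, so a modest shift in this assay is expected, leaning toward a lower number. The estimate for compound 4 is therefore 4000 nM, within 1500 nM to 11000 nM. This corresponds to an expected step of a 1.3-fold lower number from compound 3 to compound 4 (0.11 log units; within the scatter).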

Compound 4, half-maximal inhibitory concentration: 1600 nM
Estimate against measurement, compound 4: 2.5-fold (0.40 log units) above; the measured number falls inside the stated range.
By their numbers in this assay, from the lowest: compounds 4 and 1 (each within the scatter of the next); then compound 3; then compound 2.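

At this double-bonded chain carbon, 5-fluoro-2-methylphenyl gives a clear gain over 2-(trifluoromethyl)phenyl, with a 3.2-fold lower number from compound 3 to compound 4 (0.50 log units; beyond the scatter), and a larger one over 2-methoxyphenyl, with an 8.4-fold lower number from compound 2 to compound 4 (0.92 log units; beyond the scatter). The comparison with the 2,3-dichlorophenyl ring gives a 1.4-fold lower number from compound 1 to compound 4 (0.14 log units; within the scatter), so these two rings cannot be told apart in this assay. Among these four compounds, then, a ring without chlorine can match the best number seen.

No evidence is available to explain these steps, or to separate the part of the fluorine from that of the methyl. Going by these compounds, whether a ring carrying an amine or a carboxylic acid at this place would keep such numbers remains open.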